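Trading a 4-Bromophenyl Arm for Methyl

The compounds below may be only part of what the source reports. "The series", "measured", "known", "first", "only" and "open" are said of these compounds alone.

Among the measured compounds shown here, compound 1 `O=C(Nc1ccc(F)cc1)N1N=C(c2ccc(Br)cc2)CC1c1ccc(F)cc1` gives 16 nM in an assay on HEK293 cells for inhibition of Voltage-dependent T-type calcium channel subunit alpha-1H (Homo sapiens), read by FLIPR and calcium flux, with a stated time of 3 min (a higher number here means a weaker inhibitor, a lower number a stronger inhibitor), the lowest of the two numbers measured so far. Compound 2 `O=C(Nc1ccccn1)N1N=C(c2ccc(Br)cc2)CC1c1ccc(F)cc1` gives 393 nM in this assay, and the step of a 25-fold higher number from compound 1 to compound 2 (1.39 log units; beyond the scatter) is large. Compound 3 `CC1=NN(C(=O)Nc2ccc(F)cc2)C(c2ccc(F)cc2)C1` differs from compound 1 at another place: methyl in place of 4-bromophenyl on a carbon with a double bond to nitrogen. For the measured compounds named here, the only measured step concerns the group on the amide-type nitrogen, so no measured step bears directly on this change, and the range is kept wide. A weaker inhibitor is nonetheless expected, and compound 3 is estimated at 500 nM (range 100 nM to 3000 nM) in this assay. The expected step is a 31-fold higher number from compound 1 to compound 3 (1.49 log units; beyond the scatter).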

Compound 3, half-maximal inhibitory concentration: 900 nM
Compound 3: middle estimate off by 1.8-fold (0.26 log units), on the low side, and the stated range covers the measured number.
By their numbers in this assay, from the lowest: compound 1; then compound 2; then compound 3.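

Methyl in place of 4-bromophenyl gives a 56-fold higher number from compound 1 to compound 3 (1.75 log units; beyond the scatter) in this assay, so this position, which the earlier step left untouched, also bears strongly on the number. The change removes the bromine and the six-membered aromatic ring together, and so the step cannot assign the loss to either one. Nothing measured here explains the loss.

Unsubstituted phenyl or cyclohexyl at this carbon would help separate the two, and these compounds leave open whether either keeps the low number of compound 1.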